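Chloro in place of hydrogen: compound 3 to compound 4

The source may report more compounds than this note shows. Statements on the series, on what has been measured and on what is new or still open speak of the compounds shown alone.

Values in a functional assay on L1210 cells (Mus musculus) for inhibition (a higher number here means a weaker inhibitor, a lower number a stronger inhibitor), so far:
- compound 1 `C=Cc1cc(=O)[nH]c(=O)n1C1O[C@H](CO)[C@@H](O)[C@H]1O` gives 12000 nM
- compound 2 `COC(=O)/C(Br)=C\c1cc(=O)[nH]c(=O)n1C1O[C@H](CO)[C@@H](O)[C@H]1O` gives > 25000 nM as a limit, not a number
- compound 3 `C=Cc1cc(O)nc(O)n1` gives 3000 nM

Compound 3 holds the lowest number of the series, and compound 1 is its nearest neighbour, with a gap beyond the scatter. Compound 2 stands at a limit and offers no number for comparison.

The next compound is compound 4 `C=Cc1nc(O)nc(O)c1Cl` and the change is chloro in place of hydrogen on an aromatic carbon with chloro in place of hydrogen on an aromatic carbon, ortho to a vinyl group and ortho to a hydroxy group.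

Among the measured compounds shown here, the one measured step is an at least 2.0-fold higher number from compound 1 to compound 2 (0.31 log units; beyond the scatter) and it alters the vinyl group itself, so it gives no direct size for a change at a ring hydrogen. That step also ends at a limit (the limit of > 25000 nM in this assay, at which 1 of the 3 values shown sits) and so has no upper end. For the measured compounds named here, no measured step covers chloro, which leaves compound 3 at 3000 nM as the anchor, with a wide margin either way.

No shift beyond the scatter is expected in this assay and the estimated 1.2-fold lower number from compound 3 to compound 4 (0.08 log units; within the scatter) carries no firm direction. Compound 4 is estimated at 2500 nM with an expected range from 600 nM to 10000 nM as the working figure.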

Compound 4, half-maximal inhibitory concentration: 4500 nM
Compound 4: the middle estimate sits 1.8-fold (0.26 log units) below what was measured, within the range that was stated.
By their numbers in this assay, from the lowest: compounds 3 and 4 (each within the scatter of the next); then compound 1. At a limit, above all of these: compound 2.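

In this assay, chloro in place of hydrogen gives a 1.5-fold higher number from compound 3 to compound 4 (0.18 log units; within the scatter), so a chlorine atom on this aromatic carbon, ortho to a hydroxy group and ortho to a vinyl group, leaves the reading within the scatter. Among the compounds shown here, the earlier measured step altered the vinyl group itself, so this is the first reading at a ring carbon of the series, and it gives this position no firm direction for the change. No measured property in hand bears on this chloro step.

On these data alone, one substituent at one position cannot show how far this tolerance extends, so it remains open whether methyl, an amine or a nitrile on the same carbon would also stay within the scatter of compound 3. As far as these compounds go, it is also open whether chloro at this carbon would read the same way on the core of compound 1, which gives 12000 nM in this assay.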